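Benzamide series: fluoro for methyl on the aryl thioether

This account rests on a few compounds, and the source may have more. Where it says the series, first, only, none or still open, it means among the compounds named here.

Working notes on a small set of compounds that share one core and differ in the aryl group hung on the thioether. Among the measured compounds shown here, compound 1 `Cc1ccc(SCc2ccc(C(=O)Nc3ccccc3N)cc2)cc1` is the only member with a number: in a functional assay on HeLa cells (Homo sapiens) for antiproliferative activity, read by CCK-8 assay, with a stated time of 72 h (on this read-out higher numbers stand for weaker inhibition and lower numbers for stronger inhibition), compound 1 gives 4250 nM. Compound 2 `CC(C)(C)c1ccc(SCc2ccc(/C=C/C(=O)Nc3ccccc3N)cc2)cc1` differs from compound 1 in more than one place, and in this assay compound 2 gives "not determined" (no result reported). Compound 3 `Nc1ccccc1NC(=O)/C=C/c1ccc(CSc2cccc3ccccc23)cc1` also differs from compound 1 in more than one place, and in this assay compound 3 gives "not determined" (no result reported). Neither of them adds anything to the picture. For the measured compounds named here, no step between two measured compounds exists; the usual scatter of the read-out is the only yardstick.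

Compound 4 `Nc1ccccc1NC(=O)c1ccc(CSc2ccc(F)cc2)cc1` differs from compound 1 in one place: fluoro in place of methyl on an aromatic carbon. Nothing in the set shows how a change at this place moves the read-out. With methyl and fluoro each a single heavy atom, and no comparison to lean on, a step beyond the scatter in either direction is not expected. The expected step of a 1.1-fold higher number from compound 1 to compound 4 (0.02 log units; within the scatter) is therefore essentially flat. Compound 4 is estimated at 4500 nM in this assay, with a range from 1800 nM to 11000 nM.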

Compound 4, half-maximal inhibitory concentration: 5010 nM
Beside the measured number, compound 4's estimate is 1.1-fold (0.05 log units) below it; low and high end bracket the measured number.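

Among the compounds shown here, the first step at this place is now on record: in this assay, fluoro in place of methyl on an aromatic carbon gives a 1.2-fold higher number from compound 1 to compound 4 (0.07 log units; within the scatter) and so cannot be told apart from no change. For the compounds shown here, at this position, then, exchanging one single heavy atom for another leaves the antiproliferative read-out where it stood, which the earlier compounds alone could not show. Nothing available bears on why the two compounds read alike.

From the compounds shown here alone, whether an amine, a carboxylic acid or a longer chain on this same aromatic carbon would move the read-out beyond the scatter remains open. A single step at a single place also leaves open whether the exchange of methyl for fluoro would read as flat on another core.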